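The compounds below may be only part of what the source reports. "The series", "measured", "known", "first", "only" and "open" are said of these compounds alone.

In an ADME assay on MT4 cells (Homo sapiens) for cytotoxicity, read by MTT assay (a higher number here means that more compound is tolerated, a lower number that less compound is tolerated), compound 1 (`Cc1ccc(NC(=O)CSc2nncnc2-c2cccc3ccccc23)c(Br)c1`) gives 166000 nM and compound 2 (`O=C(CSc1nncnc1-c1cccc2ccccc12)Nc1cccnc1Cl`) gives 44000 nM as the lower of the two numbers. The unmeasured compound 3 (`O=C(CSc1nncnc1-c1cccc2ccccc12)Nc1ccccc1F`) carries 2-fluorophenyl in place of 2-chloropyridin-3-yl on an amide-type nitrogen. For the measured compounds named here, only one measured step bears on this change: a 3.8-fold lower number from compound 1 to compound 2 (0.58 log units; beyond the scatter) goes with 2-chloropyridin-3-yl in place of 2-bromo-4-methylphenyl. Compound 3 gives up that group and returns to a ring of carbon only, as in compound 1 (166000 nM), but 2-fluorophenyl is not the group of compound 1, so only part of that step is expected to reverse. In this assay a modest step to a higher number is expected (a 2.0-fold higher number from compound 2 to compound 3 (0.31 log units; beyond the scatter)). Compound 3 is estimated at 90000 nM (expected range 35000 nM to 230000 nM).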

Compound 3, half-maximal cytotoxic concentration: 65000 nM
Compound 3: middle estimate off by 1.4-fold (0.14 log units), on the high side; the range from low to high includes it.
By their numbers in this assay, from the lowest: compounds 2 and 3 (each within the scatter of the next); then compound 1.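

In this assay, the exchange at the amide-type nitrogen gives a 1.5-fold higher number from compound 2 to compound 3 (0.17 log units; within the scatter), so 2-fluorophenyl and 2-chloropyridin-3-yl cannot be told apart here, and a ring of carbon only does not by itself separate from the pyridine ring. The gap to the 2-bromo-4-methylphenyl group remains, with a 2.6-fold lower number from compound 1 to compound 3 (0.41 log units; beyond the scatter), so the higher number of compound 1 goes with that particular group and not with every ring of carbon only. No measurement in hand gives a cause for either step.

On these data alone, whether the bromine or the methyl of compound 1 carries this gap stays open, as the two change together in these compounds. Also open, as far as these compounds go, is how the number responds to an unsubstituted phenyl, or to a ring bearing an amine or a carboxylic acid, at this nitrogen.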